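The compounds below may be only part of what the source reports. "The series", "measured", "known", "first", "only" and "open" are said of these compounds alone.

The three compounds measured share one core and differ only in the group carried on a saturated chain carbon bound to a carbonyl carbon. Compound 3 `CC(C)[C@H](NC(=O)COc1cccc2ccccc12)C(=O)N[C@@H](CC(=O)O)C(=O)CSc1nc2ccccc2[nH]1` in a functional assay on Jurkat cells (Homo sapiens) for inhibition (a lower number here means a stronger inhibitor, a higher number a weaker inhibitor), gives only a limit, > 200000 nM, and not a number. Compound 1 `CC(C)c1cc(OCC(=O)[C@H](CC(=O)O)NC(=O)[C@@H](NC(=O)COc2cccc3ccccc23)C(C)C)no1` also gives a limit in this assay, > 200000 nM. Compound 2 `CC(C)[C@H](NC(=O)COc1cccc2ccccc12)C(=O)N[C@@H](CC(=O)O)C(=O)CSc1nc(-c2ccccc2)no1` gives 102000 nM. Two of the three values thus sit at one boundary: the limit of > 200000 nM in this assay, at which 2 of the 3 values shown sit. The steps among them are small or unreadable: an at least 1.9-fold lower number from compound 1 to compound 2 (0.29 log units; that floor lies within the scatter), an at least 1.9-fold higher number from compound 2 to compound 3 (0.29 log units; that floor lies within the scatter) and a step that the two limits leave unreadable from compound 1 to compound 3. Compound 4 `CC(C)[C@H](NC(=O)COc1cccc2ccccc12)C(=O)N[C@@H](CC(=O)O)C(=O)COn1nnc2ccccc21` carries a group of 10 heavy atoms (6 carbon, 3 nitrogen, 1 oxygen; one five-membered aromatic ring with 3 hetero atoms, one six-membered aromatic ring of carbon only) in place of a group of 10 heavy atoms (7 carbon, 2 nitrogen, 1 sulfur; one five-membered aromatic ring with 2 hetero atoms, one six-membered aromatic ring of carbon only), on a saturated chain carbon bound to a carbonyl carbon. Within the data shown here, no measured step covers this entering group, and the three changes already made at the same place moved the number by nothing the scatter could separate. Compound 4 is therefore expected to give about 200000 nM, within 80000 nM to 500000 nM, most probably again as a limit rather than a number. The expected step of a number no higher from compound 3 to compound 4 (the limit leaves the size open) is none beyond the scatter.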

Compound 4, half-maximal inhibitory concentration: > 200000 nM
Compound 4 ended at the assay's limit (the forecaster's own chance of this, stated with the estimate: 60%); the middle value lies on the limit itself.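

In this assay compound 4 gives > 200000 nM, which is a limit and not a number. Among these compounds, replacing (1H-benzimidazol-2-yl)sulfanyl with a group of the same heavy-atom count, with 0 hydrogen-bond donors and 4 hydrogen-bond acceptors, therefore produced no readable gain, and the values gather further at one boundary: the limit of > 200000 nM in this assay, at which 3 of the 4 values shown sit. The one readable new step is an at least 1.9-fold higher number from compound 2 to compound 4 (0.29 log units; that floor lies within the scatter), while the other new steps, each joining two limits, cannot be read.

As far as these compounds go, what a phenoxy group or an aliphatic amine would give on this saturated chain carbon bound to a carbonyl carbon stays open, as does whether any group there can give a number clearly separated from the limit. From the compounds shown here alone, the effect of a change elsewhere on the shared core also remains open.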